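A few compounds are considered here, and "the series" means these few. Any claim that something is new, unique, unknown or untested is made for them only; others in the source may bear on it.

Measured so far in a functional assay on MIA PaCa-2 cells (Homo sapiens) for inhibition, read by MTT assay, with a stated time of 72 h; on this read-out higher numbers stand for weaker inhibition and lower numbers for stronger inhibition:
compound 1 `COc1cc(NC(C)CCCNC(=O)Nc2cccc(F)c2)c2ncccc2c1` gives 22000 nM
compound 2 `COc1cc(NC(C)CCCNC(=O)Nc2cccc(O)c2)c2ncccc2c1` gives 46000 nM
compound 3 `COc1cc(NC(C)CCCNC(=O)NNC(=O)Nc2cc(C(F)(F)F)cc(C(F)(F)F)c2)c2ncccc2c1` gives 20000 nM

Compound 2 at 46000 nM stands highest of the three, making it the weakest inhibitor here. The change to compound 4 `COc1cc(NC(C)CCCNC(=O)NNC(=O)Nc2ccc(O)cc2)c2ncccc2c1` is ((4-hydroxyphenyl)carbamoyl)amino in place of 3-hydroxyphenyl on an amide-type nitrogen and nothing else differs. Within the data shown here, the only measured step, a 2.1-fold higher number from compound 1 to compound 2 (0.32 log units; beyond the scatter) for hydroxy in place of fluoro, was modest and concerns another group, so it bears only loosely. Compound 3 at 20000 nM carries the same carbamoyl-amino extension with a different aromatic end, and its number lies below that of compound 2. A small step to a lower number in this assay is therefore expected, possibly none beyond the scatter. The estimated step is a 1.5-fold lower number from compound 2 to compound 4 (0.19 log units; within the scatter) on this evidence. Compound 4 is estimated at 30000 nM with an expected range of 12000 nM to 70000 nM across repeat measurements.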

Compound 4, half-maximal inhibitory concentration: 142000 nM
Beside the measured number, compound 4's estimate is 4.7-fold (0.68 log units) below it, and the stated range ends below it.
By their numbers in this assay, from the lowest: compounds 3 and 1 (each within the scatter of the next); then compound 2; then compound 4.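

In this assay the ((4-hydroxyphenyl)carbamoyl)amino group on the amide-type nitrogen gives a 3.1-fold higher number from compound 2 to compound 4 (0.49 log units; beyond the scatter) and also a 6.5-fold higher number from compound 1 to compound 4 (0.81 log units; beyond the scatter). Among these compounds, this is the largest change so far, and it goes towards weaker inhibition. The extension alone does not set the number: compound 3 carries it with a different aromatic end and gives 20000 nM here; nothing at hand explains the shift.

Still open, on these data alone, is how much of the step comes from the extension and how much from the hydroxy group on the ring. An amine or a carboxylic acid on that ring would test the aromatic end.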